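The compounds below may be only part of what the source reports. "The series", "measured", "known", "first", "only" and "open" are said of these compounds alone.

Compound 1 `O=c1cc(-c2ccccc2)oc2cc(OCCCCNc3nc4ccc([N+](=O)[O-])cc4s3)cc(O)c12` was examined in an ADME assay on MDCK cells (Canis lupus familiaris) for cytotoxicity, read by sulforhodamine B assay, with a stated time of 48 h (on this read-out lower numbers stand for stronger inhibition and higher numbers for weaker inhibition), where compound 1 gives 310 ug/mL. Its companion, compound 2 `O=c1cc(-c2ccccc2)oc2cc(OCCCCNc3nc4ccc(F)cc4s3)cc(O)c12`, differs from it only by a fluoro in place of the nitro on an aromatic carbon; in this assay compound 2 gives 324 ug/mL. Among the measured compounds shown here, the single step between them, a 1.0-fold higher number from compound 1 to compound 2 (0.02 log units; within the scatter), shows that swapping the substituent on that aromatic carbon leaves the read-out essentially unchanged, so the two numbers sit together and neither compound can be set apart from the other.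

The change now followed leads from compound 1 to compound 3 `O=c1cc(-c2ccccc2)oc2cc(OCCCCNNc3nc4ccccc4s3)cc(O)c12`. The counted difference is (1,3-benzothiazol-2-yl)amino in place of 6-nitro-1,3-benzothiazol-2-yl on an amine nitrogen. For the measured compounds named here, no measured step in this assay covers the added linker nitrogen; the only one available, from compound 1 to compound 2, bears on the loss of the nitro and is within the scatter. On that basis no step beyond the scatter is expected in this assay, and the expected step from compound 1 to compound 3 is a 1.0-fold lower number from compound 1 to compound 3 (0.01 log units; within the scatter). Compound 3 is therefore estimated in this assay at 300 ug/mL, with a range from 150 ug/mL to 600 ug/mL.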

Compound 3, half-maximal inhibitory concentration: 316 ug/mL
Compound 3: the middle estimate sits 1.1-fold (0.02 log units) below what was measured; measured number inside the range.
By their numbers in this assay, from the lowest: compounds 1, 3 and 2 (each within the scatter of the next).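

In this assay, the exchange of 6-nitro-1,3-benzothiazol-2-yl for (1,3-benzothiazol-2-yl)amino on the amine nitrogen comes with a 1.0-fold higher number from compound 1 to compound 3 (0.01 log units; within the scatter), and the matching exchange from the 6-fluoro group comes with a 1.0-fold lower number from compound 2 to compound 3 (0.01 log units; within the scatter). The earlier pair varied only the substituent on an aromatic carbon, whereas compound 3 carries no such substituent and has one more nitrogen in the link, with the entering group counting a hydrogen-bond donor where the group it replaces counts none, and still the number stays within the scatter of both neighbours. So this place has now taken a nitro, a fluoro, an unsubstituted ring and an extra amine nitrogen without any step that can be told from the scatter, and no measurement shown here offers an explanation for this.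

Because the two changes in compound 3 arrive together, the compounds shown do not separate the loss of the substituent from the gain of the linker nitrogen. They also leave open whether a longer chain, or a carboxylic acid or a piperazine in place of the 1,3-benzothiazol-2-yl group, would move this read-out beyond the scatter.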